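Sgk1 Inhibition: Extending an Ether Substituent on the Shared Core

This account rests on a few compounds, and the source may have more. Where it says the series, first, only, none or still open, it means among the compounds named here.

Measured compounds:
compound 1 `CC(C)NC(=O)c1cc(-c2ccc(NS(=O)(=O)c3cccc(Cl)c3Cl)cc2)nc2[nH]ncc12` — 17600 nM
compound 2 `CN1CCC(CNC(=O)c2cc(-c3ccc(NS(=O)(=O)c4cccc(Cl)c4Cl)cc3)nc3[nH]ncc23)C1` — 45 nM
compound 3 `CCOc1nc(-c2ccc(NS(=O)(=O)c3cc(Cl)ccc3F)cc2)nc2[nH]nc(C)c12` — 183 nM

Of the compounds shown here, three have been measured in an assay for inhibition of serine/threonine-protein kinase Sgk1 (Homo sapiens), with stated times of 30 min and 60 min, in the presence of a further agent that is not named here; a higher number here means a weaker inhibitor, a lower number a stronger inhibitor. Among them compound 3 gives the second highest number, with 183 nM; compound 2 lies nearest to it, and compound 1 furthest. Compound 4 `Cc1n[nH]c2nc(-c3ccc(NS(=O)(=O)c4cc(Cl)ccc4F)cc3)nc(OC3CC(C)(C)N(C)C(C)(C)C3)c12` has not yet been measured. It differs from compound 3 in one place: 1,2,2,6,6-pentamethylpiperidin-4-yl in place of ethyl on an oxygen on an aromatic ring. Within the data shown here, the one measured step that bears on this change is the one from compound 1 to compound 2, where a small alkyl group on an amide-type nitrogen gave way to a larger group carrying a ring with one hetero atom, and the number fell sharply: a 390-fold lower number from compound 1 to compound 2 (2.59 log units; beyond the scatter). The change from compound 3 to compound 4 is of a similar kind, a small alkyl group replaced by a larger group containing a six-membered non-aromatic ring with 1 hetero atom and 1 hydrogen-bond acceptor, though it sits on an oxygen rather than a nitrogen and on a different core. A lower number beyond the scatter is therefore expected, though a smaller step than the measured one is the safer expectation: a 4.6-fold lower number from compound 3 to compound 4 (0.66 log units; beyond the scatter). Compound 4 is estimated to give 40 nM, with a range from 8 nM to 200 nM.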

Compound 4, half-maximal inhibitory concentration: 3 nM
Compound 4: the middle estimate sits 13-fold (1.12 log units) above what was measured; the whole stated range lies above it.
By their numbers in this assay, from the lowest: compound 4; then compound 2; then compound 3; then compound 1.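

In this assay, the change from ethoxy to (1,2,2,6,6-pentamethylpiperidin-4-yl)oxy brings a 61-fold lower number from compound 3 to compound 4 (1.79 log units; beyond the scatter). This shows that the number responds strongly to the group on an oxygen on an aromatic ring, which the earlier step, confined to a group on an amide-type nitrogen, could not show. Set beside a 390-fold lower number from compound 1 to compound 2 (2.59 log units; beyond the scatter), it gives two large steps in the same direction, each with a small alkyl group giving way to a larger group carrying a non-aromatic ring, though on different atoms and different cores, and the data offer no explanation for the size of either step.

The compounds shown leave open which part of the entering group carries the step: a cyclohexyl group, a piperidin-4-yl group without the methyl groups, or an open-chain amine such as 2-(dimethylamino)ethyl on the same oxygen would separate the ring, its nitrogen and its methyl groups. They also leave open whether the pentamethylpiperidinyl ether would give a step of like size with a different sulfonamide aryl group on the shared core.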